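A sulfur substituent swap and the solubility of compound 3

The source may hold more compounds than are shown below. What is called first, only, known or untested is meant among the compounds shown, and "the series" means these compounds.

Values measured so far in a physicochemical assay for solubility, using the shake flask method, in phosphate buffer, with a stated time of 24 h, at pH 7.4; on this read-out lower numbers stand for lower solubility and higher numbers for higher solubility
Compound 1 `O=c1c2cn(C3COC3)nc2nc(SCc2cccc(F)c2)n1-c1ccccc1` gives 5000 nM
Compound 2 `COc1cccc(C(C)Sc2nc3c(cnn3C)c(=O)n2-c2ccccc2)c1` gives < 2000 nM, which is a limit and not a number

For the measured compounds named here, compound 1, at 5000 nM, holds the only actual number among the measured compounds. Compound 2 is known only through its limit of < 2000 nM. That leaves compound 1 as the single numerical anchor for what follows.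

Compound 3 `CC(Sc1nc2nn(C3COC3)cc2c(=O)n1-c1ccccc1)c1ccccn1` keeps the core of compound 1 and carries 1-(pyridin-2-yl)ethyl in place of 3-fluorobenzyl on a sulfur. It has not yet been measured in this assay. Going by the values given here, no measured step between two compounds is available to size this change, so the expectation rests on compound 1 at 5000 nM and on the structural change alone. A small upward movement is expected, one that may not clear the usual scatter of this assay, and the expected step is a 1.6-fold higher number from compound 1 to compound 3 (0.20 log units; within the scatter). Compound 3 is estimated at 8000 nM, with an expected range of 2500 nM to 30000 nM.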

Compound 3, solubility: 60000 nM
Compound 3: middle estimate off by 7.5-fold (0.88 log units), on the low side; measured number above the stated range.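

In this assay, the substituent on a sulfur proves to be a place where the value can move well beyond the scatter: 1-(pyridin-2-yl)ethyl in place of 3-fluorobenzyl gives a 12-fold higher number from compound 1 to compound 3 (1.08 log units; beyond the scatter). For the compounds shown here, compound 2 remains known only through a limit, < 2000 nM, and it gives no readable step at this place, so this is the first measured size for a change here. No measurement shown gives a cause for the size of the step.

The step is a single comparison in which the fluorine-bearing carbon ring leaves and a ring with one nitrogen enters, on a different link to the sulfur, so what the compounds shown leave open is how much of it belongs to the ring and how much to that link. On these data alone, a pyridin-2-ylmethyl or a 1-phenylethyl group on the same sulfur, with the core of compound 1 unchanged, would separate the two parts, and whether the step holds on any other core also remains open.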